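Replacing morpholin-4-yl with hydroxy in compound 2

A few compounds are considered here, and "the series" means these few. Any claim that something is new, unique, unknown or untested is made for them only; others in the source may bear on it.

For the measured compounds named here, in a functional assay on MDA-MB-231 cells (Homo sapiens) for inhibition, read by sulforhodamine B assay, with a stated time of 72 h (on this read-out lower numbers stand for stronger inhibition of growth and higher numbers for weaker inhibition of growth), compound 1 `CCOC(=O)/C=C/c1ccncc1-c1ccc2cc[nH]c2c1` gives 7980 nM, the only true number so far. Compound 3 `O=C(O)/C=C/c1ccncc1-c1ccc2cc[nH]c2c1` gives only a limit of the assay, > 10000 nM. As far as these compounds go, compound 2 `O=C(CCc1ccncc1-c1ccc2ccccc2c1)N1CCOCC1` likewise gives only a limit, > 10000 nM, so its real position on the scale is unknown. The picture is therefore dominated by the limit of > 10000 nM in this assay, at which 2 of the 3 values shown sit.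

Compound 4 `O=C(O)CCc1ccncc1-c1ccc2ccccc2c1` differs from compound 2 by one change: hydroxy in place of morpholin-4-yl on a carbonyl carbon. Put simply, (morpholin-4-yl)carbonyl becomes carboxy, with the rest of the molecule untouched. One measured step also ends in a carboxy group, the change from the ethyl ester to the free acid, which gave an at least 1.2-fold higher number from compound 1 to compound 3 (0.09 log units; that floor lies within the scatter). It is only a loose guide, since it starts from an ester rather than an amide and sits on a different core. Even so, it offers no sign that a carboxy group brings stronger inhibition of growth. No gain beyond the scatter is therefore expected, and the estimated change is a step that the limit leaves unreadable from compound 2 to compound 4. For compound 4 the estimated value is 15000 nM, with an expected range of 9000 nM to 40000 nM, and the assay will quite likely report only a limit.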

Compound 4, concentration for 50% growth inhibition: > 10000 nM
Compound 4: no number, only a limit; the forecaster's own chance of this, stated with the estimate: 85%; the middle value lies beyond the limit too.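

Compound 2 and compound 4 each give only a limit and not a true number, so the change from morpholin-4-yl to hydroxy cannot be read as a step of any size. The compounds shown leave open where compound 2, compound 3 and compound 4 truly stand on the scale, and whether this change matters at all, as the readings stop at one point: the limit of > 10000 nM in this assay, at which 3 of the 4 values shown sit.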